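Swapping Allyl for Cyclohexyl on a Triazole Nitrogen

This account rests on a few compounds, and the source may have more. Where it says the series, first, only, none or still open, it means among the compounds named here.

Of the compounds shown here, two sharing one core have been measured in a functional assay on RAW264.7 cells (Mus musculus) for inhibition, read by Griess assay, with stated times of 2 h and 24 h; on this read-out higher numbers stand for weaker inhibition and lower numbers for stronger inhibition. Compound 1 `CCCn1cc(COc2cc(O)c3c(c2)O[C@H](c2ccc(OC)c(O)c2)C/C3=N\O)nn1` gives 2340 nM, and compound 2 `C=CCn1cc(COc2cc(O)c3c(c2)O[C@H](c2ccc(OC)c(O)c2)CC3=O)nn1` gives 13800 nM. Of these two numbers, compound 2 stands at the higher one, meaning weaker inhibition, and the gap to compound 1 is beyond the usual scatter. Because the two compounds differ in more than one place, that gap cannot be pinned to a single change.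

Compound 3 `COc1ccc([C@@H]2CC(=O)c3c(O)cc(OCc4cn(C5CCCCC5)nn4)cc3O2)cc1O` keeps the core of compound 2 and differs from it in one place: cyclohexyl in place of allyl on an aromatic nitrogen. For the measured compounds named here, no measured pair shows what this particular change does in this assay. For compound 3 the step of a 1.5-fold lower number from compound 2 to compound 3 (0.19 log units; within the scatter) is expected to be small, a mild move toward stronger inhibition that may still sit within the scatter. Compound 3 is therefore estimated at 9000 nM, with a likely range from 3000 nM to 27000 nM in this assay.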

Compound 3, half-maximal inhibitory concentration: 15600 nM
The estimate for compound 3 lay 1.7-fold (0.24 log units) below the measured number; the range from low to high includes it.
By their numbers in this assay, from the lowest: compound 1; then compounds 2 and 3 (each within the scatter of the next).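

In this assay, cyclohexyl in place of allyl on an aromatic nitrogen gives a 1.1-fold higher number from compound 2 to compound 3 (0.05 log units; within the scatter). At this position, then, a six-membered carbon ring and a smaller open group with a double bond cannot be told apart on this read-out, so the larger group brings no measurable gain or loss in inhibition for this pair. No supporting measurement on hand accounts for this result.

As far as these compounds go, both groups contain only carbon and hydrogen, so it remains open whether an amine, a carboxylic acid or a longer chain on the same nitrogen would leave the number just as unmoved. From the compounds shown here alone, it is also open whether the same swap would read alike on the core of compound 1.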